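The source may hold more compounds than are shown below. What is called first, only, known or untested is meant among the compounds shown, and "the series" means these compounds.

The compounds measured so far:

Compound 1, `CCc1cc(Nc2nc(N[C@@H](C)c3ccc(F)cc3)nc3cc(F)ccc23)n[nH]1` — 100 nM
Compound 2, `CCn1cnc(Nc2nc(N[C@@H](C)c3ccc(F)cn3)nc3cccc(F)c23)c1` — 280 nM
Compound 3, `CCc1cc(Nc2nc(N[C@@H](C)c3cccc(F)c3)nc3ccccc23)n[nH]1` — 340 nM

All three were tested in an assay on isolated protein for inhibition of G protein-coupled receptor kinase 6 (Homo sapiens), read by scintillation counting, radiometric assay and 33P incorporation, with a stated time of 80 min, in the presence of a further agent that is not named here; on this read-out lower numbers stand for stronger inhibition and higher numbers for weaker inhibition. Compound 1 stands lowest of the three numbers. Its nearest neighbour is compound 2, which gives 280 nM, a gap beyond the usual scatter; furthest away is compound 3, which gives 340 nM, also beyond the scatter. Compound 1 therefore stands apart as the strongest inhibitor among these three.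

The next compound is compound 4, `CCc1cc(Nc2nc(N[C@@H](C)c3ccc(F)cc3)nc3ccccc23)n[nH]1`. It differs from compound 1 in a single place: hydrogen in place of fluoro on an aromatic carbon. Within the data shown here, no pair of measured compounds differing only in this way has been tested, so the size of this step is unknown. Compound 3 carries the same unsubstituted core as compound 4 and gives a higher number than compound 1, but compound 3 also differs from compound 1 elsewhere, so its value shows only that much.

Compound 4 is expected to lie somewhat above compound 1, with the step of a 1.8-fold higher number from compound 1 to compound 4 (0.26 log units; within the scatter) estimated as a modest loss, possibly within the scatter. The estimate for compound 4 in this assay is 180 nM, within a range of 60 nM to 500 nM.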

Compound 4, half-maximal inhibitory concentration: 120 nM
For compound 4 the middle estimate is 1.5-fold (0.18 log units) above the measured one; measured number inside the range.
By their numbers in this assay, from the lowest: compounds 1 and 4 (each within the scatter of the next); then compounds 2 and 3 (each within the scatter of the next).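

In this assay, hydrogen in place of fluoro on the aromatic carbon of the core gives a 1.2-fold higher number from compound 1 to compound 4 (0.08 log units; within the scatter), so at this position, meta to a fused ring and para to a fused ring, the two compounds cannot be told apart. The other new step, 4-fluorophenyl in place of 3-fluorophenyl on the saturated chain carbon bound to a nitrogen on an aromatic ring and a saturated chain carbon, gives a 2.8-fold lower number from compound 3 to compound 4 (0.45 log units; beyond the scatter), which is modest but beyond the scatter, so here the place of the fluoro on the phenyl ring does separate two compounds that differ in nothing else. Nothing at hand accounts for either of these results.

The compounds shown carry only hydrogen or fluoro at the core position, so it stays open whether a methoxy group, a chloro group or an amine would be accepted there. On the saturated chain carbon, only the 3-fluorophenyl and 4-fluorophenyl groups can be compared, which leaves open how a plain phenyl or a 4-chlorophenyl group would read in this assay.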